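Ethoxy to allyloxy: the step from compound 2 to compound 4

The source may report more compounds than this note shows. Statements on the series, on what has been measured and on what is new or still open speak of the compounds shown alone.

Measured so far in an assay on CHO cells for displacement of a labelled ligand from adenosine receptor A3 (Homo sapiens), read by scintillation counting, with a stated time of 120 min, tested at 1 uM; a lower number here means less inhibition, a higher number more inhibition at the concentration tested (going by the name of the read-out):
compound 1 `N#Cc1c(N)nc(SCc2cccnc2)c(C#N)c1-c1ccc(OCC2CC2)cc1` gives 19%
compound 2 `CCOc1ccc(-c2c(C#N)c(N)nc(SCc3ccn[nH]3)c2C#N)cc1` gives 18%
compound 3 `CCOc1ccc(-c2c(C#N)c(N)nc(SCC(N)=O)c2C#N)cc1` gives 20%

Compound 2 holds the lowest of the three numbers, yet its gaps to compound 1 and to compound 3 both fall within the scatter, so no order among the three is claimed. Compound 4 `C=CCOc1ccc(-c2c(C#N)c(N)nc(SCc3ccn[nH]3)c2C#N)cc1` differs from compound 2 by vinyl in place of methyl on a saturated chain carbon bound to an oxygen on an aromatic ring. For the measured compounds named here, no measured step touches this place. Going by the values given here, the one step at hand, a number 2 percentage points higher from compound 2 to compound 3 (within the scatter), sits on a saturated chain carbon bound to a sulfur and stays within the scatter. Compound 1, which carries a different group on the same oxygen on an aromatic ring, also sits within the scatter of compound 2. The expected step of a number 2 percentage points higher from compound 2 to compound 4 (within the scatter) is therefore none beyond the scatter. For compound 4 the estimate is 20%, ranging from 8% to 32%.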

Compound 4, a percentage reported as inhibition, at one concentration (the size of the read-out at that concentration, not a potency): 13%
Compound 4: the middle estimate sits 7 percentage points above what was measured, within the range that was stated.
By their numbers in this assay, from the lowest: compounds 4, 2, 1 and 3 (each within the scatter of the next).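

In this assay, for the compounds shown here, ethoxy to allyloxy gives a number 5 percentage points lower from compound 2 to compound 4 (within the scatter), the first reading of a one-place change at this position. Replacing methyl with vinyl on a saturated chain carbon bound to an oxygen on an aromatic ring therefore opens no gap beyond the scatter. No evidence available here bears on this result. Still open, going by these compounds, is whether a longer chain or a carboxylic acid on this oxygen would move the number beyond the scatter. Also open, on these data alone, is whether allyloxy reads the same alongside the carbamoyl group of compound 3 .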